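Extending the butyl chain by one carbon in a hydroxamic acid series

The compounds below may be only part of what the source reports. "The series", "measured", "known", "first", "only" and "open" are said of these compounds alone.

Measured compounds:
- Compound 1 `CCCCN(Cc1ccc(C(=O)NO)cc1)c1ncc(-c2ccc(C)cc2)s1`: 4300 nM
- Compound 2 `Cc1ccc(-c2cnc(N(Cc3ccc(C(=O)NO)cc3)CC(C)C)s2)cc1`: 7420 nM
- Compound 3 `CCCN(Cc1ccc(C(=O)NO)cc1)c1ncc(-c2ccc(C)cc2)s1`: 2550 nM

Of the compounds shown here, three sharing one core have been tested in a functional assay on HepG2 cells (Homo sapiens) for antiproliferative activity, read by MTT assay, with a stated time of 48 h; a higher number here means a weaker inhibitor of growth, a lower number a stronger inhibitor of growth. Compound 1 carries a butyl chain on the ring nitrogen; its number lies within the scatter of compound 3 on one side and of compound 2 on the other, so no ranking among the three can be made from these values.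

Compound 4 `CCCCCN(Cc1ccc(C(=O)NO)cc1)c1ncc(-c2ccc(C)cc2)s1` is the next compound in this direction. It differs from compound 1 by methyl in place of hydrogen on a saturated chain carbon, four bonds along the chain from a nitrogen on an aromatic ring, so the butyl chain becomes a pentyl chain.

The closest measured step is a 1.7-fold lower number from compound 1 to compound 3 (0.23 log units; within the scatter), which shortens the same chain by one carbon and stays within the scatter. The step of a 2.9-fold lower number from compound 2 to compound 3 (0.46 log units; beyond the scatter) concerns a branched chain and bears less directly on a straight extension. Lengthening the chain has therefore shown no clear effect so far, and compound 4 is expected to give a number close to that of compound 1, the step of a 1.3-fold higher number from compound 1 to compound 4 (0.11 log units; within the scatter) being expected to stay within the scatter. The estimate for compound 4 is 5500 nM, with a likely range from 2500 nM to 12000 nM.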

Compound 4, concentration for 50% growth inhibition: 7020 nM
Estimate against measurement, compound 4: 1.3-fold (0.11 log units) below; the range from low to high includes it.
By their numbers in this assay, from the lowest: compounds 3, 1, 4 and 2 (each within the scatter of the next, the first and the last beyond it).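

In this assay, the step from butyl to pentyl alone stays small, with a 1.6-fold higher number from compound 1 to compound 4 (0.21 log units; within the scatter), but the wider step from the propyl chain to the pentyl chain gives a 2.8-fold higher number from compound 3 to compound 4 (0.44 log units; beyond the scatter), so chain length at this position does matter across compounds 3 and 4. The branched chain of compound 2 and the pentyl chain cannot be told apart, with a 1.1-fold lower number from compound 2 to compound 4 (0.02 log units; within the scatter). Adding a methyl at the end of the chain reads alike on the branched and the straight chains: the same change on two cores in this assay, a 2.9-fold lower number (0.46 log units; beyond the scatter) from compound 2 to compound 3 and a 1.6-fold lower number (0.21 log units; within the scatter) from compound 4 to compound 1, 1.8-fold (0.25 log units) apart, within the scatter of two such steps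

Still open, on these data alone, is whether a hexyl chain would raise the number further, or an ethyl chain lower it. Also open, as far as these compounds go, is how this assay would respond to a chain ending in an amine or a carboxylic acid.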